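The source may report more compounds than this note shows. Statements on the series, on what has been measured and on what is new or still open speak of the compounds shown alone.

Measured in a functional assay on T98G cells (Homo sapiens) for inhibition, read by MTT assay, with a stated time of 72 h; on this read-out lower numbers stand for stronger inhibition and higher numbers for weaker inhibition:
- compound 1 `CC1(C)CC(NC(=S)Nc2ccc(C#N)cc2)c2cc(F)ccc2O1`: 19000 nM
- compound 2 `CC1(C)CC(NC(=S)Nc2ccc([N+](=O)[O-])cc2)c2cc(Cl)ccc2O1`: 4000 nM

Of these two, compound 2 has the lower number, 4000 nM, which makes it the stronger inhibitor, and its gap to compound 1 lies beyond the usual scatter. The next compound to be tested is compound 3 `CC1(C)CC(NC(=S)Nc2ccc([N+](=O)[O-])cc2)c2cc(F)ccc2O1`. It has fluoro in place of chloro on an aromatic carbon of compound 2 (fluoro in place of chloro on an aromatic carbon). Within the data shown here, no two measured compounds differ in one place only, so the data show no direct size for this swap. Among the measured compounds shown here, the only hint comes from compound 1, which also carries fluoro and gives 19000 nM, although it has a nitrile where compound 3 has a nitro group. A modest rise in this assay is therefore expected, with the estimated step of a 2.0-fold higher number from compound 2 to compound 3 (0.30 log units; within the scatter). The estimate for compound 3 is 8000 nM, with an expected range of 3000 nM to 20000 nM.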

Compound 3, half-maximal inhibitory concentration: 5000 nM
Estimate against measurement, compound 3: 1.6-fold (0.20 log units) above, within the range that was stated.
By their numbers in this assay, from the lowest: compounds 2 and 3 (each within the scatter of the next); then compound 1.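

In this assay, fluoro in place of chloro on this aromatic carbon can now be read directly, and it gives a 1.3-fold higher number from compound 2 to compound 3 (0.10 log units; within the scatter), so the data do not separate these two halogens at this position. With fluoro held fixed, nitro in place of cyano gives a 3.8-fold lower number from compound 1 to compound 3 (0.58 log units; beyond the scatter), so among these three compounds, the swap of nitrile for nitro shifts the number clearly, whereas the swap of halogens does not. Nothing available explains either result.

On these data alone, whether this position accepts something other than a halogen, such as a methoxy group or a plain hydrogen, remains open. As far as these compounds go, it is also open how an amine or a carboxylic acid would compare in the place held by the nitro group.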